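Quinazoline acrylamides: oxolanyloxy in place of methoxy

The source may report more compounds than this note shows. Statements on the series, on what has been measured and on what is new or still open speak of the compounds shown alone.

Measured in a functional assay on PC-3 cells (Homo sapiens) for antiproliferative activity, read by MTT assay, with a stated time of 72 h; a higher number here means a weaker inhibitor, a lower number a stronger inhibitor: compound 1 `C/C=C/C(=O)Nc1cc2c(N3CCc4ccccc43)ncnc2cc1O[C@@H]1CCOC1` gives 5220 nM; compound 2 `CCC/C=C/C(=O)Nc1cc2c(N3CCc4ccccc43)ncnc2cc1O[C@@H]1CCOC1` gives 9230 nM; compound 3 `COc1cc2ncnc(N3CCc4ccccc43)c2cc1NC(=O)/C=C/CN1CCCCC1` gives 4180 nM.

Compound 3 and compound 1 lie within the scatter of each other in this assay; compound 2 lies beyond the scatter from compound 3. Compound 4 `O=C(/C=C/CN1CCCCC1)Nc1cc2c(N3CCc4ccccc43)ncnc2cc1O[C@@H]1CCOC1` differs from compound 3 by oxolan-3-yl in place of methyl on an oxygen on an aromatic ring. Going by the values given here, no measured pair shows this change; the only measured step, a 1.8-fold higher number from compound 1 to compound 2 (0.25 log units; within the scatter), concerns the chain on the amide and is within the scatter. Compound 1 and compound 3, which share the oxolanyloxy-free or chain-free half of this comparison, are also within the scatter of each other. No step beyond the scatter is therefore expected, a 1.1-fold higher number from compound 3 to compound 4 (0.03 log units; within the scatter). Compound 4 is estimated at 4500 nM, between 1800 nM and 11000 nM.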

Compound 4, half-maximal inhibitory concentration: 4510 nM
For compound 4 the middle estimate is 1.0-fold (0.00 log units) below the measured one; the measured number falls inside the stated range.
By their numbers in this assay, from the lowest: compounds 3, 4, 1 and 2 (each within the scatter of the next, the first and the last beyond it).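

In this assay oxolan-3-yl in place of methyl on the oxygen on the aromatic ring stays within the scatter (a 1.1-fold higher number from compound 3 to compound 4 (0.03 log units; within the scatter)), so this position accepts the ring with piperidin-1-yl on the chain. On the saturated chain carbon, piperidin-1-yl in place of hydrogen also stays within the scatter (a 1.2-fold lower number from compound 1 to compound 4 (0.06 log units; within the scatter)), while piperidin-1-yl in place of ethyl modestly exceeds it (a 2.0-fold lower number from compound 2 to compound 4 (0.31 log units; beyond the scatter)). Nothing measured here explains these readings.

On these data alone, whether morpholin-4-yl or dimethylamino in place of piperidin-1-yl would give a step beyond the scatter stays open. As far as these compounds go, the opposite stereocentre of the oxolan-3-yl group also stays open.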